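A few compounds are considered here, and "the series" means these few. Any claim that something is new, unique, unknown or untested is made for them only; others in the source may bear on it.

Measured in a functional assay on U-251 cells (Homo sapiens) for cytotoxicity; a lower number here means a stronger inhibitor of growth, a higher number a weaker inhibitor of growth:
Compound 1 `COc1ccc(C2=C(c3ccc(SC)cc3)CC3CCCN3C2=O)cc1OC(=O)C1CCCN1C(=O)OC(C)(C)C`: 2000 nM
Compound 2 `CSc1ccc(C2=C(c3ccc(F)c(C)c3)C(=O)N3CCCC3C2)cc1`: 200 nM

Compound 2 gives the lower of the two numbers, 200 nM, and its gap to compound 1 lies beyond the scatter. Compound 1 differs from compound 2 in more than one place, so it offers little guidance for the next comparison.

Compound 3 `CSc1ccc(C2=C(c3ccc(C)cc3)C(=O)N3CCCC3C2)cc1` differs from compound 2 in one place: 4-methylphenyl in place of 4-fluoro-3-methylphenyl on a double-bonded ring carbon. The swap is on a double-bonded ring carbon. The group that leaves and the group that enters each have one six-membered aromatic ring of carbon only, with no hydrogen-bond donors or acceptors and no net charge. For the measured compounds named here, no measured pair shows what this swap does, so no step beyond the scatter is expected in this assay. The estimated change is a 1.3-fold higher number from compound 2 to compound 3 (0.10 log units; within the scatter). The value expected for compound 3 is 250 nM, with an estimated range of 90 nM to 700 nM.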

Compound 3, concentration for 50% growth inhibition: 400 nM
Compound 3: middle estimate off by 1.6-fold (0.20 log units), on the low side, within the range that was stated.
By their numbers in this assay, from the lowest: compounds 2 and 3 (each within the scatter of the next); then compound 1.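

For the compounds shown here, putting 4-methylphenyl in place of 4-fluoro-3-methylphenyl on the double-bonded ring carbon gives in this assay a 2.0-fold higher number from compound 2 to compound 3 (0.30 log units; within the scatter) and so provides the first comparison at this position that changes only one place, which compound 1 could not offer. Removing the fluorine from this aromatic ring therefore produces no difference that can be separated from ordinary variation between repeated measurements, and a single swap this small says little about how other groups would behave here. Nothing available explains this result or shows what the fluorine does in other settings.

A group of a different kind, such as an amine or a carboxylic acid on this phenyl ring, remains an open test of whether the position can produce a step beyond the scatter. A plain phenyl or a 4-fluorophenyl group would also help separate the contribution of the methyl from that of the fluorine.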